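A few compounds are considered here, and "the series" means these few. Any claim that something is new, unique, unknown or untested is made for them only; others in the source may bear on it.

Measured compounds:
compound 1, `CSc1nn(-c2ccccc2)c2nc(Nc3ccccc3)n(-c3ccccc3)c(=O)c12`: 36.6%
compound 2, `CSc1nn(-c2ccc([N+](=O)[O-])cc2)c2nc(Nc3ccccc3)n(-c3ccccc3)c(=O)c12`: 37.7%

In a functional assay on the whole organism (strain Wistar albino) for inhibition, with Rattus norvegicus as the target, read by paw edema, with a stated time of 2 h, at a dose of 25 mg/kg by the oral route (on this read-out lower numbers stand for less inhibition and higher numbers for more inhibition at the one dose given (going by the name of the read-out)), compound 1 gives 36.6% and compound 2 gives 37.7%. Compound 2 stands with compound 1 at numbers that the step of a number 1.1 percentage points higher from compound 1 to compound 2 (within the scatter) shows to lie within the scatter, so the two compounds cannot be told apart on this read-out, even though the number of compound 2 is the one that appears larger of the two.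

Compound 3, `CSc1nn(-c2ccc(S(N)(=O)=O)cc2)c2nc(Nc3ccccc3)n(-c3ccccc3)c(=O)c12`, is not yet measured. It differs from compound 2 by sulfamoyl in place of nitro on an aromatic carbon. Among the measured compounds shown here, the only measured step that bears on this place is the one from compound 1 to compound 2, where nitro replaced hydrogen on the same aromatic carbon: a number 1.1 percentage points higher from compound 1 to compound 2 (within the scatter). That exchange left the read-out essentially unchanged. Because a number 1.1 percentage points higher from compound 1 to compound 2 (within the scatter) stayed within the scatter, a further exchange at that same place is expected to move the number little as well, with no clear direction.

The step from compound 2 to compound 3 is therefore estimated as a number 0.3 percentage points higher from compound 2 to compound 3 (within the scatter). Compound 3 is expected to give 38%, between 28% and 48%.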

Compound 3, a percentage reported as inhibition, in the whole organism at one dose (the size of the read-out at that dose, not a potency): 54.1%
For compound 3 the middle estimate is 16.1 percentage points below the measured one; the whole stated range lies below it.
By their numbers in this assay, from the lowest: compounds 1 and 2 (each within the scatter of the next); then compound 3.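

The earlier pair left open whether this aromatic carbon, para to a large group, matters at all in this assay, but the sulfamoyl group shows that it does, with a number 16.4 percentage points higher from compound 2 to compound 3 (beyond the scatter) and with a number 17.5 percentage points higher from compound 1 to compound 3 (beyond the scatter). The place is therefore not indifferent to what it carries: hydrogen and nitro cannot be told apart there, whereas sulfamoyl stands clear of both, so the flat first step reflected those two groups and not the position as a whole. Sulfamoyl differs from nitro in carrying a sulfur atom and a hydrogen-bond donor, but nothing available shows whether either feature accounts for the higher number, and no independent measurement explains the change.

Going by these compounds, it remains open whether the rise is particular to sulfamoyl or would also appear with a methylsulfonyl group, a carboxylic acid or an amine on the same carbon. The compounds shown also leave open whether the order of the three compounds would hold at another dose or another time in this assay.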